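This account rests on a few compounds, and the source may have more. Where it says the series, first, only, none or still open, it means among the compounds named here.

Measured compounds in a functional assay on MDA-MB-231 cells (Homo sapiens) for antiproliferative activity, read by sulforhodamine B assay, with a stated time of 48 h; a lower number here means a stronger inhibitor, a higher number a weaker inhibitor:
compound 1 `COc1ccc(C(=O)/C=C\Nc2ccc(-c3nc4cc(OC)c(OC)c(OC)c4s3)cc2C)cc1O`: 12400 nM
compound 2 `COc1ccc(C(=O)/C=C\Nc2ccc(-c3nc4cc(OC)c(OC)c(OC)c4s3)cc2)cc1O`: 18100 nM
compound 3 `COc1ccc2nc(-c3ccc(N/C=C\C(=O)c4ccc(OC)c([N+](=O)[O-])c4)cc3)sc2c1`: 17600 nM

Compound 1 and compound 2 share one core and differ by methyl in place of hydrogen on an aromatic carbon; that change gave a 1.5-fold lower number from compound 2 to compound 1 (0.16 log units; within the scatter). Compound 3 is built on a different core; how it differs from compound 2 is not broken down here, and the two numbers lie within the usual scatter of each other, so nothing can be said about an order between them.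

Compound 4 `COc1ccc2nc(-c3ccc(N/C=C\C(=O)c4ccc(OC)c([N+](=O)[O-])c4)c(C)c3)sc2c1` is not yet measured and relates to compound 3 by methyl in place of hydrogen on an aromatic carbon. This is the same kind of change as that from compound 2 to compound 1, but not the same change: the place differs in what the methyl stands meta to, a large group in the earlier pair and a 6-methoxy-1,3-benzothiazol-2-yl group here. With a single earlier instance to go on, the step of a 1.4-fold lower number from compound 3 to compound 4 (0.15 log units; within the scatter) is expected to be small, because in this assay the earlier pair gave a 1.5-fold lower number from compound 2 to compound 1 (0.16 log units; within the scatter). For compound 4 the estimate in this assay is 12500 nM, with a range from 6000 nM to 26000 nM.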

Compound 4, half-maximal inhibitory concentration: 17600 nM
The estimate for compound 4 lay 1.4-fold (0.15 log units) below the measured number; the measured number falls inside the stated range.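

In this assay, methyl in place of hydrogen on an aromatic carbon gave no change at the digits printed from compound 3 to compound 4 (within the scatter), while the earlier pair gave a 1.5-fold lower number from compound 2 to compound 1 (0.16 log units; within the scatter). Set side by side, the two steps do not differ, so on these two cores the change carries over as a step that stays within the scatter: the same change on two cores in this assay, a 1.5-fold lower number (0.16 log units; within the scatter) from compound 2 to compound 1 and no change at the digits printed (within the scatter) from compound 3 to compound 4, 1.5-fold (0.16 log units) apart, within the scatter of two such steps. Within the data shown here, this rests on only two pairs in a single assay, so it does not show that the step would stay this small on any further core, and a real effect smaller than the scatter could not be seen in either pair.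

From the compounds shown here alone, whether an ethyl group, a chlorine or an amine on the same aromatic carbon would move the number beyond the scatter remains open. Among these compounds, also open is what the hydroxy and nitro groups on the aryl ketone contribute separately, since compound 2 and compound 3 differ in more than one place and no pair here isolates either group.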